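The source may report more compounds than this note shows. Statements on the series, on what has been measured and on what is new or still open speak of the compounds shown alone.

Measured in an assay on FRT cells for positive allosteric modulation of Cystic fibrosis transmembrane conductance regulator variant N1303K (Homo sapiens), in the presence of a further agent that is not named here; a lower number here means that less compound is needed, a higher number that more compound is needed for the effect:
compound 1 `COc1ccc2[nH]c3c(c2c1)CCNC31CCN(Cc2ccc([N+](=O)[O-])cc2F)CC1`: 5900 nM
compound 2 `COc1ccc2[nH]c3c(c2c1)CCNC31CCN(Cc2cc(F)cc(Cl)c2)CC1`: 2500 nM
compound 3 `COc1ccc2[nH]c3c(c2c1)CCNC31CCN(Cc2ccc(Br)cc2F)CC1`: 1600 nM

Compound 3 has the lowest number of the three; one step toward it is a 1.6-fold lower number from compound 2 to compound 3 (0.19 log units; within the scatter), and the other is a 3.7-fold lower number from compound 1 to compound 3 (0.57 log units; beyond the scatter). Compound 4 `COc1ccc2[nH]c3c(c2c1)CCNC31CCN(Cc2cc(F)ccc2F)CC1` differs from compound 3 by 2,5-difluorophenyl in place of 4-bromo-2-fluorophenyl on a saturated chain carbon bound to an amine nitrogen in a ring. The step that bears most directly on this is from compound 1 to compound 3, a 3.7-fold lower number from compound 1 to compound 3 (0.57 log units; beyond the scatter), which shows that exchanging the group on that aromatic carbon matters; the step from compound 2 to compound 3, a 1.6-fold lower number from compound 2 to compound 3 (0.19 log units; within the scatter), shows that rearranging halogens on the ring matters little. Removing the bromine is expected to cost somewhat, so compound 4 is estimated at 3200 nM (range 1200 nM to 9000 nM), an expected 2.0-fold higher number from compound 3 to compound 4 (0.30 log units; within the scatter) in this assay.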

Compound 4, half-maximal effective concentration: 11100 nM
Compound 4: the middle estimate sits 3.5-fold (0.54 log units) below what was measured, outside the stated range (above it).
By their numbers in this assay, from the lowest: compounds 3 and 2 (each within the scatter of the next); then compounds 1 and 4 (each within the scatter of the next).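

Not every halogen pattern on this ring serves equally: moving to 2,5-difluorophenyl gives a 6.9-fold higher number from compound 3 to compound 4 (0.84 log units; beyond the scatter) and a 4.4-fold higher number from compound 2 to compound 4 (0.65 log units; beyond the scatter), although compound 2 and compound 3 lie within the scatter of each other. The same change gives a 1.9-fold higher number from compound 1 to compound 4 (0.27 log units; within the scatter), so compound 1 and compound 4 cannot be told apart here. Nothing measured here explains the gap between these halogen patterns. As far as these compounds go, it remains open whether the bromo group itself or the whole halogen pattern accounts for the gap in compound 3. From the compounds shown here alone, how an amine or a carboxylic acid on this ring would fare also remains open.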